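This account rests on a few compounds, and the source may have more. Where it says the series, first, only, none or still open, it means among the compounds named here.

Measured compounds: compound 1 `COc1ccc(/C=C/C(=N\O)c2ccc(OC)cc2)cc1` gives 12300 nM in a functional assay (Mus musculus, strain Balb/c) for inhibition, read by ELISA, with a stated time of 72 h; a higher number here means a weaker inhibitor, a lower number a stronger inhibitor; compound 2 `COc1ccc(/C=C/C(=N\O)c2ccc(Cl)cc2)cc1` gives 5850 nM; compound 3 `Cc1ccc(C(/C=C/c2ccc(Br)cc2)=N/O)cc1` gives 11600 nM.

Compound 3 stands second highest of the three numbers; its gap to compound 1 is within the scatter, and its gap to compound 2 is also within the scatter. Compound 4 `COc1ccc(/C=C/C(=N\O)c2ccc(C)cc2)cc1` differs from compound 3 by methoxy in place of bromo on an aromatic carbon. Within the data shown here, the one measured step that bears on this change runs the opposite way, halogen replacing methoxy: a 2.1-fold lower number from compound 1 to compound 2 (0.32 log units; beyond the scatter). Reversing that exchange, a modest rise or a step within the scatter is expected, a 1.4-fold higher number from compound 3 to compound 4 (0.14 log units; within the scatter). Compound 4 is therefore estimated at 16000 nM, in the range 7000 nM to 36000 nM.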

Compound 4, half-maximal inhibitory concentration: 6240 nM
The estimate for compound 4 lay 2.6-fold (0.41 log units) above the measured number; measured number below the stated range.
By their numbers in this assay, from the lowest: compounds 2, 4, 3 and 1 (each within the scatter of the next, the first and the last beyond it).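

In this assay, putting methoxy in place of bromo on an aromatic carbon, para to a large group, gives a 1.9-fold lower number from compound 3 to compound 4 (0.27 log units; within the scatter); the exchange at this place therefore brings no step beyond the scatter. On the other side of the shared core, methyl in place of chloro gives a 1.1-fold higher number from compound 2 to compound 4 (0.03 log units; within the scatter), and methyl in place of methoxy gives a 2.0-fold lower number from compound 1 to compound 4 (0.29 log units; within the scatter). Methyl thus stays within the scatter of both groups, although chloro and methoxy are separated by a step beyond it.

No measurement shown explains these steps. Going by these compounds, how an amine or a carboxylic acid at the place held by bromo in compound 3 would fare remains open.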